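The source may hold more compounds than are shown below. What is called first, only, known or untested is meant among the compounds shown, and "the series" means these compounds.

Measured compounds:

Compound 1, `O=C(Nc1cc(-c2ccccc2)nc(-c2ccccc2)n1)c1ccccc1`: 671 nM
Compound 2, `CCCCC(=O)Nc1cc(-c2ccccc2)nc(-c2ccccc2)n1`: 109 nM

Both compounds share one core and differ only in the group on the carbonyl carbon of the amide. In an assay on CHO cells for displacement of a labelled ligand from adenosine receptor A1 (Homo sapiens) (a lower number here means a stronger inhibitor, a higher number a weaker inhibitor), compound 1 gives 671 nM, while compound 2 gives 109 nM. The one measured step is a 6.2-fold lower number from compound 1 to compound 2 (0.79 log units; beyond the scatter), so compound 2 stands at the lower of the two numbers shown, and the other compound, compound 1, lies clearly above it.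

Compound 3, `CC(C)CC(=O)Nc1cc(-c2ccccc2)nc(-c2ccccc2)n1`, is the next step. It is built from the same atoms as compound 2, joined differently: isopropyl in place of propyl on a saturated chain carbon bound to a carbonyl carbon. Going by the values given here, the only measured step, from compound 1 to compound 2, exchanged a ring for an open chain; it says nothing about branching of a chain that keeps its size, so no measured step bears directly on this change. With that, the expectation for compound 3 is a step that stays within the usual scatter, a 1.1-fold higher number from compound 2 to compound 3 (0.04 log units; within the scatter). Compound 3 is therefore estimated at 120 nM in this assay, with a likely range from 40 nM to 400 nM.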

Compound 3, inhibition constant: 14.8 nM
Compound 3: the middle estimate sits 8.1-fold (0.91 log units) above what was measured; measured number outside the range, below it.
By their numbers in this assay, from the lowest: compound 3; then compound 2; then compound 1.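

Moving one carbon so that isopropyl stands in place of propyl on a saturated chain carbon bound to a carbonyl carbon gives a 7.4-fold lower number from compound 2 to compound 3 (0.87 log units; beyond the scatter) in this assay, so this position responds to how the same atoms are joined, not only to how many there are. Against the phenyl group of compound 1, the isobutyl group gives a 45-fold lower number from compound 1 to compound 3 (1.66 log units; beyond the scatter), a larger step than the one printed for the straight butyl chain, a 6.2-fold lower number from compound 1 to compound 2 (0.79 log units; beyond the scatter), and compound 3 has the lowest number of the three. Nothing measured here explains why the branched chain and the straight chain differ.

From the compounds shown here alone, it remains open whether the number would keep falling with a tert-butyl group, a cyclopentyl ring or a longer branched chain on the same carbonyl carbon. Going by these compounds, it is also open whether the isobutyl group would give a step of similar size if the shared core carried another group elsewhere, such as an amine or a fluorine atom.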